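The compounds below may be only part of what the source reports. "The series", "measured", "known", "first", "only" and "open" are said of these compounds alone.

Measured so far, in a toxicity assay on HeLa cells (Homo sapiens) for cytotoxicity, read by colorimetric assay, with a stated time of 72 h; on this read-out higher numbers stand for lower toxicity in this test and lower numbers for higher toxicity in this test:
Compound 2 `CN(CCCO)c1nc(=O)c2cc(C(F)(F)F)cc([N+](=O)[O-])c2s1`: 103000 nM
Compound 1 `N#Cc1cccc(N2CCN(c3nc(=O)c4cc(C(F)(F)F)cc([N+](=O)[O-])c4s3)CC2)c1`: a limit of the assay, > 108000 nM

Among the measured compounds shown here, compound 2 carries the only number recorded in this assay; the value for compound 1 is a limit, at which one of the two results sits (the limit of > 108000 nM in this assay, at which 1 of the 2 values shown sits), so compound 2 cannot be ranked against it. Compound 3 `CCCCCCN(C)c1nc(=O)c2cc(C(F)(F)F)cc([N+](=O)[O-])c2s1` differs from compound 2 in one place: propyl in place of hydroxy on a saturated chain carbon, three bonds along the chain from a nitrogen on an aromatic ring. For the measured compounds named here, no measured pair shows a change of this kind, so the expected size of the step rests on the structural change alone. The hydroxy that leaves is the single hydrogen-bond donor and acceptor of the chain, and the propyl that enters lengthens the chain to hexyl; without any measured step of this sort, the account treats the step from compound 2 to compound 3 as expected to be modest and towards lower numbers, as a 1.7-fold lower number from compound 2 to compound 3 (0.23 log units; within the scatter). Compound 3 is therefore estimated at 60000 nM, with a range from 20000 nM to 150000 nM, and it remains possible that this assay again reports only a limit.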

Compound 3, half-maximal cytotoxic concentration: 75500 nM
Compound 3: the middle estimate sits 1.3-fold (0.10 log units) below what was measured; the measured number falls inside the stated range.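

In this assay, among the compounds shown here, the exchange gives the first measured step at this position, on a saturated chain carbon, three bonds along the chain from a nitrogen on an aromatic ring, and it reads as a 1.4-fold lower number from compound 2 to compound 3 (0.13 log units; within the scatter). Exchanging hydroxy for propyl turns 3-hydroxypropyl into hexyl and takes away the hydrogen-bond donor and acceptor counted for hydroxy, yet this single exchange does not separate compound 2 and compound 3 beyond the usual scatter in this test. Compound 1 remains a limit, so no step to it can be read: the limit of > 108000 nM in this assay, at which 1 of the 3 values shown sits.

The compounds shown leave open whether an amine or a carboxylic acid in place of hydroxy at this place, or a chain longer than hexyl, would give a step beyond the scatter. They also leave open how a methyl ether or a fluorine at the same chain carbon would read in this assay.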